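The source may hold more compounds than are shown below. What is called first, only, known or untested is meant among the compounds shown, and "the series" means these compounds.

Among the compounds with values here, compound 1, `C=C(c1ccc(Cl)cc1Cl)C1COC(C)(C)OO1`, is the only member of this set with a numerical reading: in a functional assay on BEAS-2B cells (Homo sapiens) for inhibition, read by MTT assay, with a stated time of 72 h (on this read-out higher numbers stand for weaker inhibition and lower numbers for stronger inhibition), compound 1 gives 68600 nM. Compound 2, `C=C(c1ccc(F)c(F)c1)C1COC(C)(C)OO1`, gives no number in this assay; for compound 2 the result is a limit of the assay, > 100000 nM. Within the data shown here, compound 1 therefore stands as the sole quantified value, the other entry being (the limit of > 100000 nM in this assay, at which 1 of the 2 values shown sits). Compound 3, `C=C(c1ccc(Cl)c(Cl)c1Cl)C1COC(C)(C)OO1`, differs from compound 1 by chloro in place of hydrogen on an aromatic carbon. Among the measured compounds shown here, with no measured step of this kind to draw on, the expected step from compound 1 to compound 3 is a 1.2-fold lower number from compound 1 to compound 3 (0.10 log units; within the scatter), no larger than the scatter. Compound 3 is thus estimated at 55000 nM, within 20000 nM to 130000 nM.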

Compound 3, half-maximal inhibitory concentration: 10200 nM
The estimate for compound 3 lay 5.4-fold (0.73 log units) above the measured number; measured number below the stated range.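

In this assay, chloro in place of hydrogen on this aromatic carbon, ortho to two chloro groups and meta to a large group, gives a 6.7-fold lower number from compound 1 to compound 3 (0.83 log units; beyond the scatter). Within the data shown here, this is the first step in the set that can be read, and it shows that the number responds to a change at this carbon. Nothing among the measurements given explains why the number moves.

On these data alone, whether a methyl, a methoxy or an amine on this same carbon would move the number as chloro does stays open. So does whether chloro at this carbon gives a similar step on a ring carrying other substituents.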